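The source may report more compounds than this note shows. Statements on the series, on what has been measured and on what is new or still open speak of the compounds shown alone.

In a functional assay on HeLa cells (Homo sapiens) for antiproliferative activity, read by MTT assay, with a stated time of 48 h (a higher number here means a weaker inhibitor, a lower number a stronger inhibitor), three compounds sharing a core have been measured. Compound 1 `Cc1cc2nc(NC(c3cn(-c4ccccc4)nc3-c3ccc([N+](=O)[O-])cc3)c3c(O)ccc4ccccc34)sc2cc1C` gives 14700 nM, compound 2 `O=[N+]([O-])c1ccc(-c2nn(-c3ccccc3)cc2C(Nc2nc3ccccc3s2)c2c(O)ccc3ccccc23)cc1` gives 6810 nM, and compound 3 `COc1ccc2nc(NC(c3cn(-c4ccccc4)nc3-c3ccc(Cl)cc3)c3c(O)ccc4ccccc34)sc2c1` gives 5200 nM. Compound 3 thus stands level with compound 2, the two lying within the scatter of each other, while its number is clearly lower than that of compound 1.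

Compound 4 `COc1ccc2nc(NC(c3cn(-c4ccccc4)nc3-c3ccc([N+](=O)[O-])cc3)c3c(O)ccc4ccccc34)sc2c1` differs from compound 3 in one place: nitro in place of chloro on an aromatic carbon. This is nitro in place of chloro on an aromatic carbon, para to a large group, so that 4-chlorophenyl becomes 4-nitrophenyl.

For the measured compounds named here, the only measured step between two compounds differing in one place, a 2.2-fold lower number from compound 1 to compound 2 (0.33 log units; beyond the scatter), is modest and lies elsewhere in the molecule, so it says nothing directly about this exchange. Going by the values given here, no measured pair isolates chloro against nitro. The two compounds that already carry 4-nitrophenyl give only indirect guidance: compound 2 lies within the scatter of compound 3, and compound 1 lies beyond it on the higher side. A small rise at most is therefore expected in this assay, with the estimated 1.3-fold higher number from compound 3 to compound 4 (0.13 log units; within the scatter) not clearly exceeding the scatter. For compound 4 the expected value is 7000 nM, with an estimated range of 3000 nM to 15000 nM.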

Compound 4, half-maximal inhibitory concentration: 5540 nM
The estimate for compound 4 lay 1.3-fold (0.10 log units) above the measured number; low and high end bracket the measured number.
By their numbers in this assay, from the lowest: compounds 3, 4 and 2 (each within the scatter of the next); then compound 1.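

In this assay, for the compounds shown here, the step of a 1.1-fold higher number from compound 3 to compound 4 (0.03 log units; within the scatter) gives the first direct reading of this exchange: with 6-methoxy-1,3-benzothiazol-2-yl held in place, 4-chlorophenyl and 4-nitrophenyl cannot be told apart on this read-out. With 4-nitrophenyl held in place, the new compound also gives two further readings: methoxy in place of hydrogen on an aromatic carbon leaves the number within the scatter, at a 1.2-fold lower number from compound 2 to compound 4 (0.09 log units; within the scatter), whereas 6-methoxy-1,3-benzothiazol-2-yl in place of 5,6-dimethyl-1,3-benzothiazol-2-yl gives a 2.7-fold lower number from compound 1 to compound 4 (0.42 log units; beyond the scatter), a modest step that lies beyond the scatter and points the same way as the earlier step away from the dimethyl compound. No available evidence accounts for either the flat exchange or the modest step.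

The compounds shown leave open whether this position responds to anything other than chloro and nitro, such as an amine or a carboxylic acid on the same aromatic carbon. They also leave open whether chloro and nitro would remain indistinguishable alongside 1,3-benzothiazol-2-yl or 5,6-dimethyl-1,3-benzothiazol-2-yl on the amine nitrogen.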